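A Methoxy-to-Cyano Swap Among Weak Antagonists

A few compounds are considered here, and "the series" means these few. Any claim that something is new, unique, unknown or untested is made for them only; others in the source may bear on it.

Within the data shown here, compound 1 (`Cc1cc(OCCCOc2ccccc2)cc2oc(=O)c([N+](=O)[O-])c(O)c12`) is the only measured compound with an exact number: in a functional assay on ileum (Cavia porcellus) for antagonist activity (on this read-out higher numbers stand for weaker inhibition and lower numbers for stronger inhibition), compound 1 gives 5200 nM. For compound 2 (`CCc1cc2c(O)c([N+](=O)[O-])c(=O)oc2cc1OCCCOc1ccccc1`), the result is a limit and not a number: > 10000 nM. Compound 3 (`COc1ccc(OCCCOc2ccc3c(O)c([N+](=O)[O-])c(=O)oc3c2)cc1`) also has only a limit: > 4000 nM. Compound 4 (`N#Cc1ccc(OCCCOc2ccc3c(O)c([N+](=O)[O-])c(=O)oc3c2)cc1`) has cyano in place of methoxy on an aromatic carbon. Among the measured compounds shown here, no measured pair shows the effect of this swap in this assay, so only a small step towards weaker inhibition is expected, with none beyond the scatter. The estimated change is a step that the limit leaves unreadable from compound 3 to compound 4. The estimate for compound 4 is 6000 nM, with an expected range of 2000 nM to 18000 nM.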

Compound 4, half-maximal inhibitory concentration: > 10000 nM
Compound 4: a limit, no number; the forecaster's own chance of this, stated with the estimate: 55%; middle value at least 1.6-fold (0.22 log units) from the limit.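

Among these compounds, compound 3 and compound 4 both carry only limits of the assay, and no step between them can be read. The compounds shown leave open whether cyano in place of methoxy changes inhibition at all in this assay.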